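Chloro removal and tolerated concentration in a cytotoxicity assay

The source may hold more compounds than are shown below. What is called first, only, known or untested is meant among the compounds shown, and "the series" means these compounds.

Measured compounds:
Compound 1 `COc1c(Br)cccc1C(=O)Nc1ccc(Sc2nc3ccccc3s2)cc1`: > 100000 nM
Compound 2 `COc1c(Br)cccc1C(=O)Nc1ccc(Sc2nc3ccccc3s2)c(Cl)c1`: > 100000 nM
Compound 3 `O=C(Nc1cccc(Cl)c1)c1cccc(Br)c1O`: 32000 nM

In an ADME assay on HEK293 cells (Homo sapiens) for cytotoxicity, read by reporter gene assay and resazurin assay, with a stated time of 48 h (a higher number here means that more compound is tolerated, a lower number that less compound is tolerated), compound 1 gives > 100000 nM, which is a limit of the assay and not a number. In this assay compound 2 likewise gives > 100000 nM, again a limit. Among the compounds with values here, compound 3 is the only one with a number; in this assay compound 3 gives 32000 nM.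

From compound 2 to compound 1 the change is hydrogen in place of chloro on an aromatic carbon, and the step that the two limits leave unreadable from compound 2 to compound 1 cannot be read, since the limit of > 100000 nM in this assay, at which 2 of the 3 values shown sit, covers both values. The difference between the core of compound 2 and the core of compound 3 is not broken down here.

Compound 4 `O=C(Nc1ccccc1)c1cccc(Br)c1O` is not yet measured. It differs from compound 3 by hydrogen in place of chloro on an aromatic carbon; this is the same kind of change as that from compound 2 to compound 1, though there the hydrogen enters at a place that is also ortho to a large group. With the measured step unreadable, the expectation rests only on the value of compound 3, 32000 nM, and a small step of a 1.3-fold higher number from compound 3 to compound 4 (0.10 log units; within the scatter) is expected. Compound 4 is therefore estimated at 40000 nM, between 15000 nM and 100000 nM.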

Compound 4, half-maximal cytotoxic concentration: 82000 nM
Estimate against measurement, compound 4: 2.1-fold (0.31 log units) below; measured number inside the range.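

In this assay, hydrogen in place of chloro on an aromatic carbon now has a readable size on one core, where the chloro sat meta to a large group: a 2.6-fold higher number from compound 3 to compound 4 (0.41 log units; beyond the scatter). This step is modest and beyond the scatter, but it is a single pair and shows the change only on the core shared by compound 3 and compound 4, so it does not establish that the same size carries over to another core in this series. The corresponding step from compound 2 to compound 1 cannot be read, and so offers no comparison, because neither compound gives a number, only a limit of the assay: the limit of > 100000 nM in this assay, at which 2 of the 4 values shown sit.

The compounds shown leave open whether an amine or a carboxylic acid on that aromatic carbon would move the tolerated concentration in the same direction as hydrogen does. They also leave open how the change behaves on any core where both partners give numbers.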